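This account rests on a few compounds, and the source may have more. Where it says the series, first, only, none or still open, it means among the compounds named here.

Compound 3 `NS(=O)(=O)c1ccc(N2N=C(c3ccc(Oc4ccccc4)cc3)CC2c2cccc(Cl)c2)cc1` stands second highest of the three numbers measured in an ADME assay on BHK-21 cells (Mesocricetus auratus) for cytotoxicity, read by MTT assay, with a stated time of 72 h (a lower number here means that less compound is tolerated, a higher number that more compound is tolerated), where compound 3 gives 9000 nM. Compound 2 `NS(=O)(=O)c1ccc(N2N=C(c3ccc(Oc4ccccc4)cc3)CC2c2ccccc2)cc1` gives 11000 nM and compound 1 `NS(=O)(=O)c1ccc(N2N=C(c3ccc(Oc4ccccc4)cc3)CC2c2ccc(Cl)cc2)cc1` gives 7000 nM; every step among them stays inside the scatter, as a 1.6-fold higher number from compound 1 to compound 2 (0.20 log units; within the scatter), a 1.3-fold higher number from compound 1 to compound 3 (0.11 log units; within the scatter) and a 1.2-fold lower number from compound 2 to compound 3 (0.09 log units; within the scatter) show. The step to compound 4 `Cc1ccccc1C1CC(c2ccc(Oc3ccccc3)cc2)=NN1c1ccc(S(N)(=O)=O)cc1` is 2-methylphenyl in place of 3-chlorophenyl on a saturated ring carbon. The most closely related step, a 1.3-fold higher number from compound 1 to compound 3 (0.11 log units; within the scatter), also moved one aryl group on the saturated ring carbon, and the chloro steps were likewise small, so no shift beyond the scatter is expected in this assay. Compound 4 is therefore estimated at 9000 nM, within 4500 nM to 18000 nM, an expected step of no change at the digits printed from compound 3 to compound 4 (within the scatter).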

Compound 4, half-maximal cytotoxic concentration: 7000 nM
Estimate against measurement, compound 4: 1.3-fold (0.11 log units) above; the range from low to high includes it.
By their numbers in this assay, from the lowest: compounds 1, 4, 3 and 2 (each within the scatter of the next).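

At this saturated ring carbon in this assay, a methyl group on the phenyl ring gives no step beyond the scatter: 2-methylphenyl in place of 3-chlorophenyl gives a 1.3-fold lower number from compound 3 to compound 4 (0.11 log units; within the scatter) and in place of 4-chlorophenyl gives no change at the digits printed from compound 1 to compound 4 (within the scatter). Against the unsubstituted phenyl, methyl in place of hydrogen gives a 1.6-fold lower number from compound 2 to compound 4 (0.20 log units; within the scatter). No supporting data bear on these numbers. Going by these compounds, whether a carboxylic acid or an amine on this phenyl ring, or a longer chain in place of it, would move the number beyond the scatter remains open.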